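The source may hold more compounds than are shown below. What is called first, only, known or untested is meant among the compounds shown, and "the series" means these compounds.

Measured in an ADME assay on HFF cells (Homo sapiens) for cytotoxicity, read by MTT assay, with a stated time of 72 h; a lower number here means a stronger inhibitor, a higher number a weaker inhibitor:

- compound 1 `O=C1O[C@H]([C@@H](O)Cn2cc(-c3cc(C(F)(F)F)cc(C(F)(F)F)c3)nn2)C(OCc2ccccc2)=C1OCc1ccccc1` gives 80700 nM
- compound 2 `CCCCc1cn(C[C@H](O)[C@H]2OC(=O)C(OCc3ccccc3)=C2OCc2ccccc2)nn1` gives 26300 nM
- compound 3 `CC(C)(C)c1cn(C[C@H](O)[C@H]2OC(=O)C(OCc3ccccc3)=C2OCc2ccccc2)nn1` gives 13300 nM

On these numbers, compound 3 at 13300 nM lies within the scatter of compound 2 at 26300 nM in this series. Compound 1 at 80700 nM has the highest number of the three.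

Compound 4 `C[Si](C)(C)c1cn(C[C@H](O)[C@H]2OC(=O)C(OCc3ccccc3)=C2OCc2ccccc2)nn1` remains to be measured in this assay and differs from compound 3 by one change: a group of 4 heavy atoms (3 carbon, 1 silicon; no ring) in place of a group of 4 heavy atoms (4 carbon; no ring), on an aromatic carbon on an aromatic carbon of the five-membered aromatic ring with 3 nitrogen.

Among the compounds with values here, the one measured step at this carbon, a 2.0-fold lower number from compound 2 to compound 3 (0.30 log units; within the scatter), is the closest guide. Tert-butyl is itself the group that leaves here, and no measured compound carries silicon, so the data offer no direct precedent. No step beyond the scatter is therefore expected.

The estimated outcome is a 1.1-fold lower number from compound 3 to compound 4 (0.04 log units; within the scatter) in this assay.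

For compound 4 the expected value is 12000 nM, with an estimated range from 5500 nM to 27000 nM when it is measured.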

Compound 4, half-maximal inhibitory concentration: 20000 nM
Compound 4: middle estimate off by 1.7-fold (0.22 log units), on the low side; the measured number falls inside the stated range.
By their numbers in this assay, from the lowest: compounds 3, 4 and 2 (each within the scatter of the next); then compound 1.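

In this assay, placing one silicon atom in the group on this aromatic carbon, in place of a carbon of tert-butyl, gives a 1.5-fold higher number from compound 3 to compound 4 (0.18 log units; within the scatter), so this position tolerates the exchange without a step beyond the scatter. The silicon-bearing group also sits within the scatter of butyl, with a 1.3-fold lower number from compound 2 to compound 4 (0.12 log units; within the scatter), so the three groups of 4 heavy atoms, branched or not and with or without silicon, cannot be told apart in this assay. No measurement shown bears on why these values lie so close together.

Going by these compounds, it remains open whether a methyl group, an amine or a carboxylic acid on this carbon would give a step beyond the scatter. On these data alone, it also remains open whether the same exchange of carbon for silicon would give a similarly small step in a longer chain.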